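Notes on the series: ring swap on the side chain of compound 3

The source may report more compounds than this note shows. Statements on the series, on what has been measured and on what is new or still open speak of the compounds shown alone.

All numbers come from an in vitro functional assay on cells for agonist activity at Bombesin receptor subtype-3 (Mus musculus), read by luminescence and calcium flux; a lower number here means that less compound is needed, a higher number that more compound is needed for the effect. Compound 1 `CCCCc1cnc(C(CCCO)Cc2ccc(-c3ccccc3C(=O)O)cc2)[nH]1` gives 238 nM. Within the data shown here, compound 2 `CCCCc1cnc(C(CC)Cc2ccc(-c3ccccc3C(=O)O)cc2)[nH]1` gives 340 nM; the step of a 1.4-fold higher number from compound 1 to compound 2 (0.15 log units; within the scatter) is the only measured pair in the set that differs in one place, and it is within the scatter. Compound 3 `O=C(O)c1ccccc1-c1ccc(CCc2ncc(CC3CCCCC3)[nH]2)cc1` gives 7.3 nM, the lowest of the three numbers, and its separation from compound 1 and from compound 2 lies beyond the scatter in both cases, so compound 3 is the most potent of the measured compounds.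

Compound 4 `O=C(O)c1ccccc1-c1ccc(CCc2ncc(CCc3ccccc3)[nH]2)cc1` differs from compound 3 by benzyl in place of cyclohexyl on a saturated chain carbon bound to an aromatic carbon. Among the measured compounds shown here, the one measured step, a 1.4-fold higher number from compound 1 to compound 2 (0.15 log units; within the scatter), concerns a hydroxymethyl on a chain at a different position and says nothing about the exchange of a six-membered non-aromatic ring for an aromatic one; no measured pair covers that exchange. With nothing in the data pointing either way, no step beyond the scatter is assumed, though the uncertainty is wide in both directions. Compound 4 is therefore expected near 12 nM, with a range from 3 nM to 50 nM, meaning an expected step of a 1.6-fold higher number from compound 3 to compound 4 (0.22 log units; within the scatter).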

Compound 4, half-maximal effective concentration: 174 nM
Compound 4: the middle estimate sits 15-fold (1.16 log units) below what was measured, outside the stated range (above it).
By their numbers in this assay, from the lowest: compound 3; then compounds 4, 1 and 2 (each within the scatter of the next).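

In this assay, the place on a saturated chain carbon bound to an aromatic carbon turns out to be sensitive to the group it carries: benzyl in place of cyclohexyl gives a 24-fold higher number from compound 3 to compound 4 (1.38 log units; beyond the scatter) for this one exchange. Among these compounds, the only earlier step, which concerned a hydroxymethyl at a different position, stayed within the scatter, so this is the first large change tied to a single place. The exchange leaves the counted hydrogen-bond donors and acceptors at 0 and the net charge at none, and it alters two things at once, the ring going from non-aromatic to aromatic and the group going from 6 heavy atoms to 7, while nothing available gives a reason for the loss.

These two alterations remain tied together in the compounds shown, so the step cannot be assigned to either one alone. A phenyl in place of the cyclohexyl would hold the heavy-atom count closer to that of compound 3 while making the ring aromatic, and a cyclohexylethyl group would add the chain carbon while keeping the ring non-aromatic.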